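The compounds below may be only part of what the source reports. "The series", "measured", "known", "first", "only" and "open" are said of these compounds alone.

Measured compounds:
- compound 1, `Cc1cc(N2CC[C@@H](C)[C@@H](N(C)c3ncnc4[nH]ccc34)C2)n2ncnc2n1`, in a toxicity assay on GES1 cells (Homo sapiens) for inhibition, read by MTT assay, with a stated time of 72 h (a higher number here means a weaker inhibitor, a lower number a stronger inhibitor), gives 57900 nM
- compound 2, `Cc1cc(N2CC[C@@H](C)[C@@H](N(C)c3ncnc4[nH]ccc34)C2)n2nc(SCC3CC3)nc2n1`, gives 27900 nM
- compound 3, `Cc1cc(N2CC[C@@H](C)[C@@H](N(C)c3ncnc4[nH]ccc34)C2)n2nc(SCc3cc(Cl)ccc3Cl)nc2n1`, gives 87500 nM

Among these three, compound 2 has the lowest number: compound 1 sits a step away by a 2.1-fold lower number from compound 1 to compound 2 (0.32 log units; beyond the scatter) read in reverse, and compound 3 is the furthest, a 3.1-fold higher number from compound 2 to compound 3 (0.50 log units; beyond the scatter).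

Compound 4, `Cc1cc(N2CC[C@@H](C)[C@@H](N(C)c3ncnc4[nH]ccc34)C2)n2nc(SCc3ccc(F)c(Cl)c3)nc2n1`, has not yet been measured. It differs from compound 2 in one place: 3-chloro-4-fluorophenyl in place of cyclopropyl on a saturated chain carbon bound to a sulfur.

Within the data shown here, one measured step bears directly on this change, the one from compound 2 to compound 3, where a different dichlorophenyl replaced the same cyclopropyl on the same carbon bound to sulfur: a 3.1-fold higher number from compound 2 to compound 3 (0.50 log units; beyond the scatter). The step from compound 1 to compound 3 (a 1.5-fold higher number from compound 1 to compound 3 (0.18 log units; within the scatter)) also shows that a benzylsulfanyl group gave a number not far from the unsubstituted compound 1. Among the measured compounds shown here, for compound 4 a modest rise in the number is therefore expected, on the order of a 2.3-fold higher number from compound 2 to compound 4 (0.37 log units; beyond the scatter), though the two halogen patterns differ and only one example exists. The estimate for compound 4 is 65000 nM, with a likely range from 30000 nM to 130000 nM.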

Compound 4, half-maximal inhibitory concentration: > 100000 nM
Compound 4 was reported as a limit; the forecaster's own chance of this, stated with the estimate: 10%; at least 1.5-fold (0.18 log units) between middle value and limit.
By their numbers in this assay, from the lowest: compound 2; then compounds 1 and 3 (each within the scatter of the next). At a limit, above all of these: compound 4.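

In this assay, among these compounds, compound 4 gives > 100000 nM, which is a limit of the assay and not a number: the limit of > 100000 nM in this assay, at which 1 of the 4 values shown sits. Replacing cyclopropyl with 3-chloro-4-fluorophenyl on the saturated chain carbon bound to a sulfur gives an at least 3.5-fold higher number from compound 2 to compound 4 (0.55 log units; beyond the scatter), so a second halogenated phenyl group now stands higher than cyclopropyl at this place, where compound 3 was the only example before. The other two steps, an at least 1.1-fold higher number from compound 3 to compound 4 (0.05 log units; that floor lies within the scatter) and an at least 1.7-fold higher number from compound 1 to compound 4 (0.23 log units; that floor lies within the scatter), are only floors and settle no order.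

As far as these compounds go, whether 3-chloro-4-fluorophenyl and 2,5-dichlorophenyl differ at all in this assay stays open. Also open, from the compounds shown here alone, is how an amine, a carboxylic acid or a longer chain at this place would read.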